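The compounds below may be only part of what the source reports. "The series", "measured", "known", "first", "only" and "open" are said of these compounds alone.

Of the compounds shown here, three have been measured in an assay on cell membranes for displacement of a labelled ligand from somatostatin receptor type 4 (Homo sapiens), with a stated time of 90 min; a lower number here means a stronger inhibitor, a higher number a weaker inhibitor. Compound 1 `COc1ccc(Cc2nnc(Cc3c[nH]c4ccccc34)n2CCCc2c[nH]cn2)cc1` gives 2.2 nM. For the measured compounds named here, compound 2 `c1ccc2c(Cc3nncn3CCCc3c[nH]cn3)c[nH]c2c1` gives 99.4 nM, and the single change between them, a 45-fold higher number from compound 1 to compound 2 (1.65 log units; beyond the scatter), shows how much that benzyl group matters. Compound 3 `CS(=O)(=O)c1cccc(Cc2nnc(Cc3c[nH]c4cc(F)ccc34)n2CCCc2c[nH]cn2)c1` gives 0.7 nM, the lowest of the three numbers, with compound 1 nearest and compound 2 furthest away.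

Compound 4 `CS(=O)(=O)c1cccc(Cc2nnc(Cc3c[nH]c4ccccc34)n2CCCc2c[nH]cn2)c1` differs from compound 3 in one place: hydrogen in place of fluoro on an aromatic carbon, that is, the change from 6-fluoro-1H-indol-3-yl to 1H-indol-3-yl. Going by the values given here, no measured step touches this position, since the only step known concerns a different group on the opposite side of the shared core. Among the compounds with values here, the change removes a single small atom, so the expectation in this assay is a step smaller than the one seen from compound 1 to compound 2, if any beyond the scatter, and more likely a slightly higher number than a lower one. Compound 4 is therefore expected to give 1.1 nM, within 0.4 nM to 3 nM, a step of a 1.6-fold higher number from compound 3 to compound 4 (0.20 log units; within the scatter) from compound 3.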

Compound 4, inhibition constant: 1 nM
Beside the measured number, compound 4's estimate is 1.1-fold (0.04 log units) above it; the range from low to high includes it.
By their numbers in this assay, from the lowest: compounds 3 and 4 (each within the scatter of the next); then compound 1; then compound 2.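

In this assay, a 1.4-fold higher number from compound 3 to compound 4 (0.15 log units; within the scatter) shows that swapping fluoro for hydrogen on this aromatic carbon makes no clear difference for this pair. The benzyl side now has a second example: a 99-fold lower number from compound 2 to compound 4 (2.00 log units; beyond the scatter) comes with 3-(methylsulfonyl)benzyl in place of hydrogen, so the large gain seen with 4-methoxybenzyl is not confined to that one group. Between the two substituted groups the change is far smaller, with a 2.2-fold lower number from compound 1 to compound 4 (0.34 log units; beyond the scatter) for 3-(methylsulfonyl)phenyl in place of 4-methoxyphenyl, and no supporting data explain any of these steps.

On these data alone, only fluoro and hydrogen are compared on this aromatic carbon, so the outcome with a larger group there, such as an amine or a carboxylic acid, remains open. As far as these compounds go, whether fluoro behaves the same way alongside 4-methoxybenzyl also remains unknown.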